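Swapping One Aromatic Group on Compound 2

The source may report more compounds than this note shows. Statements on the series, on what has been measured and on what is new or still open speak of the compounds shown alone.

In a functional assay on DU-145 cells (Homo sapiens) for inhibition, read by trypan blue exclusion, with a stated time of 96 h (on this read-out lower numbers stand for stronger inhibition of growth and higher numbers for weaker inhibition of growth), compound 2 (`Cc1ccsc1/C=C(/SCc1ccc(Cl)cc1)C(=O)c1ccc(Cl)cc1`) gives 50000 nM as its value. Compound 1 (`Cc1ccc(S(=O)(=O)/C(=C/c2ccc(O)c([N+](=O)[O-])c2)C(=O)c2ccc(Cl)cc2)cc1`) gives 25000 nM in the same test, and that lies within the usual scatter of compound 2, so the two cannot be ranked. Compound 3 (`O=C(/C(=C\c1ccc(O)c([N+](=O)[O-])c1)SCc1ccc(Cl)cc1)c1ccc(Cl)cc1`) has not yet been measured. It differs from compound 2 in one place, with 4-hydroxy-3-nitrophenyl in place of 3-methylthiophen-2-yl on a double-bonded chain carbon bound to a double-bonded chain carbon. Among the measured compounds shown here, no measured pair shows what this swap does. For the measured compounds named here, the only hint is compound 1 (25000 nM), which also carries 4-hydroxy-3-nitrophenyl but differs elsewhere too. A small move toward stronger inhibition, not clearly beyond the scatter, is expected (a 2.0-fold lower number from compound 2 to compound 3 (0.30 log units; within the scatter)). For compound 3 the estimated value is 25000 nM with an expected range from 8000 nM to 60000 nM in this assay for now.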

Compound 3, concentration for 50% growth inhibition: 10000 nM
Estimate against measurement, compound 3: 2.5-fold (0.40 log units) above; measured number inside the range.
By their numbers in this assay, from the lowest: compound 3; then compounds 1 and 2 (each within the scatter of the next).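

In this assay, 4-hydroxy-3-nitrophenyl in place of 3-methylthiophen-2-yl gives a 5.0-fold lower number from compound 2 to compound 3 (0.70 log units; beyond the scatter), which shows that the choice of aromatic group at this double-bonded chain carbon can change the read-out by more than the usual scatter. With 4-hydroxy-3-nitrophenyl held constant, (4-chlorobenzyl)sulfanyl in place of (4-methylphenyl)sulfonyl gives a 2.5-fold lower number from compound 1 to compound 3 (0.40 log units; beyond the scatter), so the group at this second place also has a measurable effect. Nothing measured here accounts for either step.

Still open, as far as these compounds go, is which part of 4-hydroxy-3-nitrophenyl matters, a question that a plain phenyl or a 4-hydroxyphenyl at the same place could help to settle. It is also unknown how a ring carrying an amine or a carboxylic acid would compare with compound 3.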